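From methoxy to 1,3-benzothiazol-2-yl on the core of compound 1

This account rests on a few compounds, and the source may have more. Where it says the series, first, only, none or still open, it means among the compounds named here.

Compound 1 `COc1ccc(NCc2cncn2Cc2ccc(-c3ccccc3)cc2N)cc1-c1ccccc1` is the starting point of this account. In a toxicity assay on NIH3T3 cells (Mus musculus) for cytotoxicity, read by resazurin assay (on this read-out higher numbers stand for an effect only at larger amounts of compound and lower numbers for an effect already at smaller amounts), compound 1 is known only as a limit, > 1000 nM, and not as a number. Among the measured compounds shown here, the single true number in the set comes from compound 2 `COC(=O)c1ccc(NCc2cncn2Cc2ccccc2Br)cc1-c1ccccc1`, which gives 10000 nM in this assay. For the measured compounds named here, compound 2 differs from compound 1 in more than one place, so the two values define no step.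

Compound 3 `Nc1cc(-c2ccccc2)ccc1Cn1cncc1CNc1ccc(-c2nc3ccccc3s2)c(-c2ccccc2)c1` has not yet been measured. It keeps the core of compound 1, but 1,3-benzothiazol-2-yl takes the place of methoxy on an aromatic carbon, ortho to a phenyl group (1,3-benzothiazol-2-yl in place of methoxy on an aromatic carbon). Going by the values given here, no measured pair shows what a change at this place does, so the expectation rests on weak ground. Compound 1 stands at its limit, > 1000 nM. Compound 2 gives 10000 nM. For compound 3 a number on the high side of the limit of compound 1 seems the likeliest outcome. The expected step that the limit leaves unreadable from compound 1 to compound 3 therefore points modestly towards higher numbers, and a limit result is also quite possible. For compound 3 the estimated value is 5000 nM, with an expected range from 1500 nM to 20000 nM.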

Compound 3, half-maximal effective concentration: > 1000 nM
Compound 3 ended at the assay's limit; the forecaster's own chance of this, stated with the estimate: 50%; the middle value lies beyond the limit too.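

Compound 1 and compound 3 both end at a limit and not at a number, so the change from methoxy to 1,3-benzothiazol-2-yl gives no step that can be read: the limit of > 1000 nM in this assay, at which 2 of the 3 values shown sit.

The compounds shown leave open how far either compound lies beyond that limit in this assay, and whether this change moves the value at all.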